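The source may report more compounds than this note shows. Statements on the series, on what has been measured and on what is new or still open speak of the compounds shown alone.

In a functional assay on SK-OV-3 cells (Homo sapiens) for antiproliferative activity, read by MTT assay, with a stated time of 72 h (on this read-out lower numbers stand for stronger inhibition and higher numbers for weaker inhibition), the three measured compounds stand as follows.

Compound 1 `COc1cccc(-c2cccc(NC(=O)CCc3ccc4c(c3)B(O)OC4)c2)c1` gives 62000 nM.
Compound 2 `CC(=O)c1ccc(-c2cccc(NC(=O)CCc3ccc4c(c3)B(O)OC4)c2)cc1` gives only a limit of the assay, > 100000 nM.
Compound 3 `COc1cccc(-c2cccc(NC(=O)CCc3cccc4c3C(O)OC4)c2)c1` gives 61000 nM.

Compound 1 and compound 2 share one core and differ in a single place: 4-acetylphenyl in place of 3-methoxyphenyl on an aromatic carbon. That change made an at least 1.6-fold higher number from compound 1 to compound 2 (0.20 log units; that floor lies within the scatter), and the size of the step is only a floor, since compound 2 sits at the limit of > 100000 nM in this assay, at which 1 of the 3 values shown sits. Compound 3 carries a different core; how the core of compound 3 differs from the core of compound 1 is not broken down here. Compound 3 and compound 1 have values that lie within the scatter of each other, so nothing can be said of an order between them.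

Compound 4 `CC(=O)c1ccc(-c2cccc(NC(=O)CCc3cccc4c3C(O)OC4)c2)cc1` is not yet measured. It differs from compound 3 in one place: 4-acetylphenyl in place of 3-methoxyphenyl on an aromatic carbon. Among the compounds with values here, this is the same change as the one from compound 1 to compound 2, and the place is the same in every word. Compound 4 is therefore expected to show a step of about a 1.6-fold higher number from compound 3 to compound 4 (0.21 log units; within the scatter) in this assay, about the size of the earlier step, which rests on compound 1 and compound 2 giving an at least 1.6-fold higher number from compound 1 to compound 2 (0.20 log units; that floor lies within the scatter) and on compound 3 starting near compound 1. For compound 4 the estimated value is 100000 nM, with a range from 50000 nM to 250000 nM, and a good chance that, like compound 2, only a limit is reported.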

Compound 4, half-maximal inhibitory concentration: 41000 nM
Compound 4: the middle estimate sits 2.4-fold (0.39 log units) above what was measured; measured number below the stated range.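

In this assay, within the data shown here, carrying 4-acetylphenyl in place of 3-methoxyphenyl over to the core of compound 3 gives a 1.5-fold lower number from compound 3 to compound 4 (0.17 log units; within the scatter), so on this core the change leaves no step that can be told from the scatter. Set beside the same change on the core of compound 1, this step cannot be shown to agree or to disagree with the earlier one: the same change on two cores in this assay, an at least 1.6-fold higher number (0.20 log units; that floor lies within the scatter) from compound 1 to compound 2 and a 1.5-fold lower number (0.17 log units; within the scatter) from compound 3 to compound 4; the limit leaves it open whether they differ With 4-acetylphenyl on both cores, the step is an at least 2.4-fold lower number from compound 2 to compound 4 (0.38 log units; beyond the scatter), which is beyond the scatter, while the two compounds with 3-methoxyphenyl lie within the scatter of each other; this suggests that the change may not carry over unaltered, but it does not show this, since the step is only a floor resting on a limit of the assay for compound 2 and no true size is known for the change on the core of compound 1.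

The compounds shown leave open how the two cores would compare with an amine or a carboxylic acid on the aromatic ring that carries these groups, or with a longer chain in place of the present saturated chain. They also leave open whether any of this would hold in another cell line.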